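The compounds below may be only part of what the source reports. "The series", "measured", "known", "first", "only" and "open" are said of these compounds alone.

In an ADME assay on the whole organism (Mus musculus, strain CD-1) for pharmacokinetics, at a dose of 10 mg/kg by the oral route (a lower number here means less compound in the circulation, a higher number more compound in the circulation at the dose given), compound 3 `CCSc1cc([C@](O)(CCN(C)C)[C@H](c2ccccc2)c2cc3cc(Br)ccc3nc2OC)cc(SCC)n1` gives 4000 ng.h/mL as the lowest of three numbers in the series. Compound 1 `COc1cc([C@](O)(CCN(C)C)[C@@H](c2cc3cc(Br)ccc3nc2OC)c2cccc(OC)c2F)cc(OC(C)C)n1` gives 9000 ng.h/mL and compound 2 `COc1cccc([C@H](c2cc3cc(Br)ccc3nc2OC)[C@@](O)(CCN(C)C)c2cc(SC)nc(SC)c2)c1F` gives 8400 ng.h/mL in the same measurement, and compound 3 lies beyond the scatter from both.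

Compound 4 `CCSc1cc([C@](O)(CCN(C)C)[C@@H](c2cc3cc(Br)ccc3nc2OC)c2cccc(OC)c2F)cc(SCC)n1` differs from compound 3 in one place: 2-fluoro-3-methoxyphenyl in place of phenyl on a saturated chain carbon bound to an aromatic carbon and a saturated chain carbon. Among the measured compounds shown here, no measured step isolates this exchange. For the measured compounds named here, the only measured step, a 1.1-fold lower number from compound 1 to compound 2 (0.03 log units; within the scatter), lies within the scatter. It changes the group on a saturated chain carbon bound to an oxygen on a saturated carbon and two saturated chain carbons, while both compounds keep the 2-fluoro-3-methoxyphenyl. Compound 3 carries phenyl instead, but it also differs from compound 1 and compound 2 in that other group, so the gap between their values cannot be assigned to phenyl alone. Compound 4 would combine the 2-fluoro-3-methoxyphenyl with the other group of compound 3. A rise towards the values of the two compounds that carry 2-fluoro-3-methoxyphenyl is therefore expected, though with clear uncertainty. The expected size is a 1.9-fold higher number from compound 3 to compound 4 (0.27 log units; within the scatter) in the direction of more compound in the circulation. For compound 4 the estimate is 7500 ng.h/mL with an expected range from 3800 ng.h/mL to 15000 ng.h/mL.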

Compound 4, area under the concentration-time curve: 11900 ng.h/mL
Estimate against measurement, compound 4: 1.6-fold (0.20 log units) below; the measured number falls inside the stated range.
By their numbers in this assay, from the lowest: compound 3; then compounds 2, 1 and 4 (each within the scatter of the next).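

In this assay, 2-fluoro-3-methoxyphenyl in place of phenyl on a saturated chain carbon bound to an aromatic carbon and a saturated chain carbon can now be read on its own, as a 3.0-fold higher number from compound 3 to compound 4 (0.47 log units; beyond the scatter), and this is the only listed step in the series that lies beyond the scatter. With 2-fluoro-3-methoxyphenyl held constant, exchanging the group on the saturated chain carbon bound to an oxygen on a saturated carbon and two saturated chain carbons gives a 1.4-fold higher number from compound 2 to compound 4 (0.15 log units; within the scatter) and a 1.3-fold higher number from compound 1 to compound 4 (0.12 log units; within the scatter), so neither of these steps separates the compounds, any more than the earlier 1.1-fold lower number from compound 1 to compound 2 (0.03 log units; within the scatter) did. No measurement is available that accounts for the rise in circulating compound with the new group.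

On these data alone, the exchange is read once, on a single partner group, so whether it carries over to the groups of compound 1 and compound 2 remains open. A phenyl bearing the fluorine alone or the methoxy alone at this carbon would be needed to tell which part of the new group goes with the higher number, and a longer chain or an amine there would show how far the position tolerates change.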